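Iodo for isopropyl on a sulfonate ester series

This account rests on a few compounds, and the source may have more. Where it says the series, first, only, none or still open, it means among the compounds named here.

Measured compounds:
compound 1, `CC(=O)Nc1ccc(S(=O)(=O)Oc2ccccc2C(C)C)cc1`, 21000 nM
compound 2, `CC(=O)Nc1ccc(S(=O)(=O)Oc2ccccc2I)cc1`, 27000 nM
compound 3, `CC(C)c1ccccc1OS(=O)(=O)c1ccc(NC(=O)CCCl)cc1`, 14000 nM

All three were tested in a functional assay on M21 cells (Homo sapiens) for antiproliferative activity, read by sulforhodamine B assay, with a stated time of 48 h; on this read-out lower numbers stand for stronger inhibition and higher numbers for weaker inhibition. Compound 1 gives 21000 nM, compound 2 gives 27000 nM and compound 3 gives 14000 nM. The two steps among them are small: a 1.3-fold higher number from compound 1 to compound 2 (0.11 log units; within the scatter), and a 1.5-fold lower number from compound 1 to compound 3 (0.18 log units; within the scatter). Neither step stands out from the scatter, so the three compounds cannot be ranked.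

Compound 4, `O=C(CCCl)Nc1ccc(S(=O)(=O)Oc2ccccc2I)cc1`, has not yet been measured. It differs from compound 3 in one place: iodo in place of isopropyl on an aromatic carbon. The same change, made twice among these compounds, also separates compound 1 from compound 2: iodo in place of isopropyl on an aromatic carbon. The place descriptions of the two changes agree word for word, so this is the same change on a different core. The cores of compound 1 and compound 3 differ as follows: chloromethyl in place of hydrogen on a saturated chain carbon bound to a carbonyl carbon.

On the core of compound 1 the change gave a 1.3-fold higher number from compound 1 to compound 2 (0.11 log units; within the scatter), a step within the scatter. The expectation for compound 4 rests on that one step: the step is estimated to be a 1.3-fold higher number from compound 3 to compound 4 (0.11 log units; within the scatter), a similarly small move. Because compound 3 gives 14000 nM, compound 4 is expected to give about 18000 nM, with a range from 9000 nM to 36000 nM.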

Compound 4, half-maximal inhibitory concentration: 12000 nM
Estimate against measurement, compound 4: 1.5-fold (0.18 log units) above; low and high end bracket the measured number.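

Putting iodo in place of isopropyl on the core of compound 3 gave a 1.2-fold lower number from compound 3 to compound 4 (0.07 log units; within the scatter) in this assay, so the change again left the number within the scatter, and the two cores show no measurable difference in how they respond: the same change on two cores in this assay, a 1.3-fold higher number (0.11 log units; within the scatter) from compound 1 to compound 2 and a 1.2-fold lower number (0.07 log units; within the scatter) from compound 3 to compound 4, 1.5-fold (0.18 log units) apart, within the scatter of two such steps The other change, chloromethyl in place of hydrogen on the saturated chain carbon, gave a 2.3-fold lower number from compound 2 to compound 4 (0.35 log units; beyond the scatter), a modest step beyond the scatter, yet it cannot be said to act differently on the two cores, even though only this one of its two steps clears the scatter: the same change on two cores in this assay, a 1.5-fold lower number (0.18 log units; within the scatter) from compound 1 to compound 3 and a 2.3-fold lower number (0.35 log units; beyond the scatter) from compound 2 to compound 4, 1.5-fold (0.18 log units) apart, within the scatter of two such steps This shows that both changes carried across the two cores shown without a detectable difference, but it does not show that isopropyl and iodo are equivalent in general, nor that the same would hold on any further core.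

The compounds shown leave open whether a quite different group at the place of iodo, such as an amine or a carboxylic acid, would move the number more clearly. They also leave open whether a longer chain in place of chloromethyl would extend the modest step seen with compound 4.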